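Swapping an amide arm for a nitrophenyl ring

This account rests on a few compounds, and the source may have more. Where it says the series, first, only, none or still open, it means among the compounds named here.

Compound 1 `CCOC(=O)C1=Cc2ccccc2OC1(OCc1cc(-c2ccc(F)cc2F)no1)C(F)(F)F`, compound 2 `CCOC(=O)C1=Cc2ccccc2OC1(OCc1cn(CC(=O)Nc2cccc(Cl)c2)nn1)C(F)(F)F` and compound 3 `CCOC(=O)C1=Cc2ccccc2OC1(OCc1cn(CC(=O)Nc2ccc(C)cc2)nn1)C(F)(F)F` share a core and differ only in the group hanging from its ether oxygen. In a functional assay on A549 cells (Homo sapiens) for inhibition, read by MTT assay, with a stated time of 24 h (on this read-out higher numbers stand for weaker inhibition and lower numbers for stronger inhibition), compound 1 gives only a limit of the assay, > 150000 nM. Compound 2 gives 12800 nM in this assay. Going by the values given here, compound 3 gives 54300 nM, the highest of the two numbers known so far; the single measured step that leads to it, a 4.2-fold higher number from compound 2 to compound 3 (0.63 log units; beyond the scatter), is modest yet beyond the scatter.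

Compound 4 `CCOC(=O)C1=Cc2ccccc2OC1(OCc1cn(-c2ccc(F)c([N+](=O)[O-])c2)nn1)C(F)(F)F` has not yet been measured. It differs from compound 3 by 4-fluoro-3-nitrophenyl in place of ((4-methylphenyl)carbamoyl)methyl on an aromatic nitrogen. Among the compounds with values here, this is a larger alteration than the one measured step, which only exchanged one ring sitting on the amide nitrogen; here the whole amide arm is removed and a fluorinated nitrophenyl ring sits directly on the ring nitrogen. The known step therefore offers only a rough scale, and the direction of the new step cannot be read from it with confidence. The expected change is a 1.8-fold lower number from compound 3 to compound 4 (0.26 log units; within the scatter). The estimate for compound 4 in this assay is 30000 nM, between 8000 nM and 150000 nM, with a real chance that only a limit is returned.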

Compound 4, half-maximal inhibitory concentration: 11900 nM
Compound 4: middle estimate off by 2.5-fold (0.40 log units), on the high side, and the stated range covers the measured number.
By their numbers in this assay, from the lowest: compounds 4 and 2 (each within the scatter of the next); then compound 3. At a limit, above all of these: compound 1.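

In this assay, the amide arm turns out not to be required at this place, on an aromatic nitrogen of the five-membered ring with 3 nitrogen: a 4-fluoro-3-nitrophenyl ring with no amide at all, set directly on that nitrogen, gives a 4.6-fold lower number from compound 3 to compound 4 (0.66 log units; beyond the scatter). That same exchange made against the ((3-chlorophenyl)carbamoyl)methyl arm gives a 1.1-fold lower number from compound 2 to compound 4 (0.03 log units; within the scatter), so the two numbers cannot be ordered, and the size of the change depends on which arm leaves. Compound 1 stays outside these comparisons, and its value is only a limit of the assay: the limit of > 150000 nM in this assay, at which 1 of the 4 values shown sits.

The compounds shown do not separate the share of the 4-fluoro part of the new ring from that of its 3-nitro part, as the two always appear together here. They also leave open how the ring would read with an amine or a carboxylic acid where the nitro group stands, and whether a short chain between the ring and the nitrogen would move the number in either direction.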